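The source may hold more compounds than are shown below. What is called first, only, known or untested is meant among the compounds shown, and "the series" means these compounds.

In an in vitro functional assay on HEK293 cells for antagonist activity at melanin-concentrating hormone receptor 1 (Homo sapiens), read by GTPgammaS binding, with a stated time of 45 min (a higher number here means a more potent compound, by a factor of ten per unit of this negative logarithm, a lower number a less potent compound), the measured compounds are:
compound 1 `COc1ccccc1-c1ccc(CN(CC(=O)C(C)(C)O)C(=O)NC2CCN(Cc3ccc(C)cc3)CC2)cc1` with 5.43;
compound 2 `Cc1ccc(CN2CCC(CCN(Cc3ccc(-c4ccc(F)cc4)cc3)C(=O)NC(C)C)CC2)cc1` with 6.42;
compound 3 `CC(=O)OCC(C)(C)NC(=O)N(CCC1CCN(Cc2ccc(C)cc2)CC1)Cc1ccc(-c2ccc(F)cc2)cc1` with 6.39.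

Compound 3 stands second highest of the three numbers; compound 2 lies within the scatter of it, while compound 1 lies well lower, beyond the scatter. Among the measured compounds shown here, the only measured step, a number 0.03 log units lower from compound 2 to compound 3 (within the scatter), concerns another part of the molecule. Compound 4 `CC(=O)OCC(C)(C)NC(=O)N(CCC1CCN(Cc2ccc(C)cc2)CC1)Cc1ccc(-c2ccccc2)cc1` differs from compound 3 by hydrogen in place of fluoro on an aromatic carbon. For the measured compounds named here, no measured step shows this change; compound 1 differs in the same region but also elsewhere, so its value alone cannot be read as that change. The step from compound 3 to compound 4 is therefore expected to be small, a number 0.19 log units lower from compound 3 to compound 4 (within the scatter), not beyond the scatter. Compound 4 is estimated at 6.2, between 5.7 and 6.7.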

Compound 4, negative logarithm of the antagonist equilibrium constant: 6.44
Estimate against measurement, compound 4: 0.24 log units below; the range from low to high includes it.
By their numbers in this assay, from the lowest: compound 1; then compounds 3, 2 and 4 (each within the scatter of the next).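

Fluoro on this aromatic carbon, para to a large group, is not required for antagonist potency in this assay: the change from 4-fluorophenyl to phenyl gives a number 0.05 log units higher from compound 3 to compound 4 (within the scatter) and leaves the two compounds indistinguishable. This holds for the shared core carrying the acetoxymethyl group. No measurement here accounts for this result.

From the compounds shown here alone, only fluoro and hydrogen can be compared at this position, so chloro, a nitrile or a carboxylic acid remain open. Also open, going by these compounds, is whether the same change would read alike on compound 2, which lacks the acetoxymethyl group.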